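Swapping thiophen-2-yl for 1-benzofuran-2-yl on a shared core

A few compounds are considered here, and "the series" means these few. Any claim that something is new, unique, unknown or untested is made for them only; others in the source may bear on it.

Compound 1 `CN(C)c1ncnc2c1c(-c1cc3ccccc3o1)cn2[C@@H]1O[C@H](CO)[C@@H](O)[C@H]1O`: > 20000 nM
Compound 2 `Cc1ncnc2c1c(-c1cccs1)cn2[C@@H]1O[C@H](CO)[C@@H](O)[C@H]1O`: > 20000 nM

Both entries come from a functional assay on A549 cells (Homo sapiens), read by MTT assay, with a stated time of 72 h; a higher number here means a weaker inhibitor, a lower number a stronger inhibitor. For compound 2, the entry > 20000 nM is a limit and not a number. Compound 1 also gives a limit, > 20000 nM. The whole picture so far is the limit of > 20000 nM in this assay, at which 2 of the 2 values shown sit. Among the measured compounds shown here, no size of step can therefore be read from these two compounds.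

Compound 3 `Cc1ncnc2c1c(-c1cc3ccccc3o1)cn2[C@@H]1O[C@H](CO)[C@@H](O)[C@H]1O` keeps the core of compound 2 and changes one group: 1-benzofuran-2-yl in place of thiophen-2-yl on an aromatic carbon. The change sits on an aromatic carbon of a five-membered aromatic ring with 1 nitrogen. Compound 1 already carries 1-benzofuran-2-yl, and its > 20000 nM is a limit, so this group alone is not expected to bring clear activity. In this assay, no step beyond the scatter is expected in either direction, and a further limit is the likeliest result. The expected step is a number no higher from compound 2 to compound 3 (the limit leaves the size open). For compound 3 the estimated value is 20000 nM, with an expected range from 8000 nM to 40000 nM.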

Compound 3, half-maximal inhibitory concentration: > 20000 nM
Compound 3: no number, only a limit (the forecaster's own chance of this, stated with the estimate: 80%); the middle value sits exactly at the limit.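

Compound 3 gives > 20000 nM as a limit and not a number. Among the compounds shown here, no step can therefore be read between compound 3 and either compound 1 or compound 2. The compounds shown leave open how 1-benzofuran-2-yl compares with thiophen-2-yl, and methyl with dimethylamino, in this assay on the shared core.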